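This account rests on a few compounds, and the source may have more. Where it says the series, first, only, none or still open, it means among the compounds named here.

Of the compounds shown here, three on a shared core have been measured so far. Compound 1, `COc1ccc(-c2cc(C(=O)/C=C/c3ccc(C)cc3)nc3cc(-c4ccccc4)nn23)cc1OC`, gives 22200 nM in a functional assay on A549 cells (Homo sapiens) for antiproliferative activity, read by MTT assay, with a stated time of 24 h; a lower number here means a stronger inhibitor, a higher number a weaker inhibitor. Compound 2, `COc1ccc(-c2cc(C(=O)/C=C/c3cc(OC)c(OC)c(OC)c3)nc3cc(-c4ccccc4)nn23)cc1OC`, gives 15400 nM in this assay. Compound 3, `COc1cc(-c2cc(C(=O)/C=C/c3ccc(C)cc3)nc3cc(-c4ccccc4)nn23)cc(OC)c1OC`, gives 20000 nM in this assay. All three numbers lie within the scatter of one another, so no order among them is drawn.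

The change that takes compound 1 to compound 2 is 3,4,5-trimethoxyphenyl in place of 4-methylphenyl on a double-bonded chain carbon bound to a double-bonded chain carbon. The step it made is a 1.4-fold lower number from compound 1 to compound 2 (0.16 log units; within the scatter).

The cores of compound 1 and compound 3 differ as follows: methoxy in place of hydrogen on an aromatic carbon. The step that goes with that core change is a 1.1-fold lower number from compound 1 to compound 3 (0.05 log units; within the scatter).

Compound 4, `COc1cc(/C=C/C(=O)c2cc(-c3cc(OC)c(OC)c(OC)c3)n3nc(-c4ccccc4)cc3n2)cc(OC)c1OC`, has not yet been measured. Its difference from compound 3 is 3,4,5-trimethoxyphenyl in place of 4-methylphenyl on a double-bonded chain carbon bound to a double-bonded chain carbon. The place is worded identically to that of the change from compound 1 to compound 2, so this is the same change, now made on the core of compound 3 rather than on the core of compound 1. Within the data shown here, the one earlier instance of this change gave a 1.4-fold lower number from compound 1 to compound 2 (0.16 log units; within the scatter), and a step of comparable size is expected here; the expected step from compound 3 to compound 4 in this assay is a 1.4-fold lower number from compound 3 to compound 4 (0.14 log units; within the scatter), resting on that single prior instance and on the values of compound 1, compound 2 and compound 3 sitting within the scatter of each other. Compound 4 is accordingly estimated at 14500 nM in this assay, with a likely range from 7000 nM to 30000 nM.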

Compound 4, half-maximal inhibitory concentration: 25900 nM
For compound 4 the middle estimate is 1.8-fold (0.25 log units) below the measured one; low and high end bracket the measured number.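

Carried to a second core in this assay, 3,4,5-trimethoxyphenyl in place of 4-methylphenyl on a double-bonded chain carbon bound to a double-bonded chain carbon gives a 1.3-fold higher number from compound 3 to compound 4 (0.11 log units; within the scatter), and the two instances of this change agree as far as such steps can be told apart: the same change on two cores in this assay, a 1.4-fold lower number (0.16 log units; within the scatter) from compound 1 to compound 2 and a 1.3-fold higher number (0.11 log units; within the scatter) from compound 3 to compound 4, 1.9-fold (0.27 log units) apart, within the scatter of two such steps. Methoxy in place of hydrogen on an aromatic carbon, now read with the 3,4,5-trimethoxyphenyl group in place, gives a 1.7-fold higher number from compound 2 to compound 4 (0.23 log units; within the scatter), and its two instances agree in the same way: the same change on two cores in this assay, a 1.1-fold lower number (0.05 log units; within the scatter) from compound 1 to compound 3 and a 1.7-fold higher number (0.23 log units; within the scatter) from compound 2 to compound 4, 1.9-fold (0.27 log units) apart, within the scatter of two such steps. Among these compounds, every one of these steps lies within the scatter, so the agreement shows only that neither change moved the number measurably on either core; it does not show that an effect of either change carries from one core to another, since no such effect has been resolved here.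

The four compounds leave open whether any replacement of the aryl group on the chain moves the number beyond the scatter, for instance an amine, a carboxylic acid or a chlorine in place of the 3,4,5-trimethoxyphenyl methoxy groups. Also open, as far as these compounds go, is whether a change to the phenyl on the shared core, such as a fluorine or a hydroxyl on it, would do so.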